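This account rests on a few compounds, and the source may have more. Where it says the series, first, only, none or still open, it means among the compounds named here.

Measured in a physicochemical assay for solubility, measured as thermodynamic solubility, at pH 7.4; on this read-out higher numbers stand for higher solubility and lower numbers for lower solubility:
- Compound 1 `O=c1ccnc2cc(C#Cc3ccccc3)ccn12`: 16000 nM
- Compound 2 `COC(=O)N1CCOc2cc(COc3ccccc3)cnc21`: > 520000 nM, a limit and not a number

Compound 2 gives only a limit, and it stands at the limit of > 520000 nM in this assay, at which 1 of the 2 values shown sits. Compound 3 `CS(=O)(=O)N1CCOc2cc(COc3ccccc3)cnc21` has not yet been measured. It carries methylsulfonyl in place of methoxycarbonyl on a nitrogen on an aromatic ring in a ring. Going by the values given here, no measured step covers this change, so the expectation is loose. A moderate fall is expected in this assay, with the estimated step being an at least 3.4-fold lower number from compound 2 to compound 3 (0.53 log units; beyond the scatter). For compound 3 the expected value is 150000 nM, with an estimated range from 25000 nM to 520000 nM.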

Compound 3, solubility: 10000 nM
Beside the measured number, compound 3's estimate is 15-fold (1.18 log units) above it, outside the stated range (below it).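

In this assay, going by these compounds alone, methylsulfonyl in place of methoxycarbonyl on the nitrogen of the six-membered non-aromatic ring gives an at least 52-fold lower number from compound 2 to compound 3 (1.71 log units; beyond the scatter), the only step the compounds offer, so the read-out responds strongly to the group at this position even though both groups have the same heavy-atom and hydrogen-bond acceptor counts. The full size of the step stays unknown, as compound 2 gives only a limit and not a number: the limit of > 520000 nM in this assay, at which 1 of the 3 values shown sits.

Going by these compounds, whether any replacement for methoxycarbonyl would bring such a fall remains open. An acetyl group, a longer ethylsulfonyl chain or a free amine on the same nitrogen would bear on this.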